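A few compounds are considered here, and "the series" means these few. Any claim that something is new, unique, unknown or untested is made for them only; others in the source may bear on it.

Measured so far in an assay on CHO cells for agonist activity at Free fatty acid receptor 1 (Homo sapiens), read by luminescence, with a stated time of 20 s, in the presence of a further agent that is not named here; a higher number here means that more compound is needed for the effect, a lower number that less compound is needed:
compound 1 `COc1ccc(-c2cccc(COc3ccc([C@H](CC(=O)O)c4nccn4C)cc3)c2)cc1`: 440 nM
compound 2 `Cc1cc(F)ccc1-c1cccc(COc2ccc([C@H](CC(=O)O)c3nccn3C)cc2)c1`: 59 nM
compound 3 `CCc1ccccc1-c1cccc(COc2ccc([C@H](CC(=O)O)c3nccn3C)cc2)c1`: 48 nM

Compound 2 holds the second highest of the three numbers; its nearest neighbour is compound 3, with a 1.2-fold lower number from compound 2 to compound 3 (0.09 log units; within the scatter), and its furthest is compound 1, with a 7.5-fold lower number from compound 1 to compound 2 (0.87 log units; beyond the scatter). Compound 4 `Cc1ccc(F)cc1-c1cccc(COc2ccc([C@H](CC(=O)O)c3nccn3C)cc2)c1` is the unmeasured partner of compound 2; the change is 5-fluoro-2-methylphenyl in place of 4-fluoro-2-methylphenyl on an aromatic carbon. Among the compounds with values here, no measured step swaps these two groups directly. The closest guide is that compound 2 and compound 3 carry differently substituted rings at this position yet show a 1.2-fold lower number from compound 2 to compound 3 (0.09 log units; within the scatter), while compound 1 stands apart from both, as a 9.2-fold lower number from compound 1 to compound 3 (0.96 log units; beyond the scatter) shows. The step in this assay is therefore expected to be small, a 1.1-fold higher number from compound 2 to compound 4 (0.04 log units; within the scatter). Compound 4 is estimated at 65 nM, within 25 nM to 170 nM.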

Compound 4, half-maximal effective concentration: 36 nM
Compound 4: middle estimate off by 1.8-fold (0.26 log units), on the high side, within the range that was stated.
By their numbers in this assay, from the lowest: compounds 4, 3 and 2 (each within the scatter of the next); then compound 1.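

In this assay, moving from 4-fluoro-2-methylphenyl to 5-fluoro-2-methylphenyl on this aromatic carbon gives no step beyond the scatter (a 1.6-fold lower number from compound 2 to compound 4 (0.21 log units; within the scatter)), so these two fluorine placements cannot be told apart here. 5-Fluoro-2-methylphenyl is also within the scatter of 2-ethylphenyl (a 1.3-fold lower number from compound 3 to compound 4 (0.12 log units; within the scatter)), whereas 4-methoxyphenyl stands apart by a large step (a 12-fold lower number from compound 1 to compound 4 (1.09 log units; beyond the scatter)). Open, going by these compounds, is whether an amine or a longer chain on this ring would keep the number within this low group. No measurement shown here bears on why these numbers fall as they do.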